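From compound 2 to compound 3: replacing piperidin-4-yl

A few compounds are considered here, and "the series" means these few. Any claim that something is new, unique, unknown or untested is made for them only; others in the source may bear on it.

In an ADME assay on microsomes from liver (Canis lupus familiaris) for metabolic stability, read by LC-MS, tested at 1 uM (a lower number here means slower removal, a higher number faster removal of the compound), compound 1 `c1cc([C@H]2CC[C@]3(CC2)OOC2(O3)C3CC4CC(C3)CC2C4)ccc1OCCC1CCNCC1` gives 16 mL.min-1.g-1 and compound 2 `c1cc([C@H]2CC[C@]3(CC2)OOC2(O3)C3CC4CC(C3)CC2C4)ccc1OC1CCNCC1` gives 25 mL.min-1.g-1. Compound 2 is one of only two measured points in the series, and the gap between them does not separate it from compound 1: a 1.6-fold higher number from compound 1 to compound 2 (0.19 log units; within the scatter).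

Compound 3 `CC1(C)CC(O)(COc2ccc([C@H]3CC[C@]4(CC3)OOC3(O4)C4CC5CC(C4)CC3C5)cc2)CC(C)(C)N1` carries (4-hydroxy-2,2,6,6-tetramethylpiperidin-4-yl)methyl in place of piperidin-4-yl on an oxygen on an aromatic ring.

Among the measured compounds shown here, the one measured step at this place is a 1.6-fold higher number from compound 1 to compound 2 (0.19 log units; within the scatter). It exchanged 2-(piperidin-4-yl)ethyl for piperidin-4-yl and stayed within the scatter. For the measured compounds named here, no measured compound carries the hydroxy or tetramethyl substitution of the entering group, so the data give no direct guide to its effect, and the range has to stay wide. On this single step, no change beyond the scatter is expected in this assay. The expected move is a 1.3-fold lower number from compound 2 to compound 3 (0.10 log units; within the scatter). For compound 3 the estimated value is 20 mL.min-1.g-1, with an expected range of 8 mL.min-1.g-1 to 50 mL.min-1.g-1.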

Compound 3, intrinsic clearance in microsomes: < 7 mL.min-1.g-1
Compound 3: a limit, no number; the forecaster's own chance of this, stated with the estimate: 5%; at least 2.8-fold (0.45 log units) between middle value and limit.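

Exchange at this position had not yet moved the read-out beyond the scatter, but in this assay the change to (4-hydroxy-2,2,6,6-tetramethylpiperidin-4-yl)methyl gives an at least 3.5-fold lower number from compound 2 to compound 3 (0.55 log units; beyond the scatter). The position on an oxygen on an aromatic ring therefore does respond to the group it carries, and the shift holds against the longer chain as well: 4-hydroxy-2,2,6,6-tetramethylpiperidin-4-yl in place of (piperidin-4-yl)methyl gives an at least 2.2-fold lower number from compound 1 to compound 3 (0.35 log units; beyond the scatter), whereas the earlier exchange gave a 1.6-fold higher number from compound 1 to compound 2 (0.19 log units; within the scatter). The reading for compound 3 in this assay is a limit of the assay and not a number: the limit of < 7 mL.min-1.g-1 in this assay, at which 1 of the 3 values shown sits.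

The entering group differs from piperidin-4-yl by the hydroxy group, the tetramethyl substitution and the added methylene link all at once, so the compounds shown do not tell which of these carries the step. A piperidine ring with the hydroxy group alone or the tetramethyl substitution alone would separate these parts, and a carboxylic acid or an amide on the same chain would show whether the ring amine is needed at all.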